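This account rests on a few compounds, and the source may have more. Where it says the series, first, only, none or still open, it means among the compounds named here.

Measured so far:
Compound 1 `COc1ccc(-c2nnc(SCC(=O)c3ccccc3)n2-c2ccccc2)cc1OC` gives 59%.
Compound 2 `COc1ccc(-c2nnc(SC/C(=N/O)c3ccccc3)n2-c2ccccc2)cc1OC` gives 78%.
Compound 3 `CCn1c(SC/C(=N/O)c2ccccc2)nnc1-c1ccc(OC)c(OC)c1` gives 71%.

These values come from a functional assay on the whole organism (strain albino) for inhibition, with Rattus norvegicus as the target, read by paw edema, with a stated time of 5 h, at a dose of 0.28 mmol/kg by the oral route; a higher number here means more inhibition at the dose given (going by the name of the read-out), a lower number less inhibition. Compound 2 and compound 3 share everything except their cores, which differ in this way: ethyl in place of phenyl on an aromatic nitrogen; the step is a number 7 percentage points lower from compound 2 to compound 3 (within the scatter). Compound 1 arises from compound 2 by the change (a group of 8 heavy atoms (7 carbon, 1 oxygen; one six-membered aromatic ring of carbon only) in place of a group of 9 heavy atoms (7 carbon, 1 nitrogen, 1 oxygen; one six-membered aromatic ring of carbon only), on a saturated chain carbon bound to a sulfur), and this gave a number 19 percentage points lower from compound 2 to compound 1 (beyond the scatter). The unmeasured compound 4 `CCn1c(SCC(=O)c2ccccc2)nnc1-c1ccc(OC)c(OC)c1` arises from compound 3 by the change (a group of 8 heavy atoms (7 carbon, 1 oxygen; one six-membered aromatic ring of carbon only) in place of a group of 9 heavy atoms (7 carbon, 1 nitrogen, 1 oxygen; one six-membered aromatic ring of carbon only), on a saturated chain carbon bound to a sulfur), the same change at the same place. Within the data shown here, the expected step is a number 19 percentage points lower from compound 3 to compound 4 (beyond the scatter), set beside the earlier one, because a number 19 percentage points lower from compound 2 to compound 1 (beyond the scatter) is the only measured instance of this change and the cores of compound 2 and compound 3 behaved alike in this assay. Compound 4 is therefore expected to give about 52%, estimated between 36% and 68%.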

Compound 4, a percentage reported as inhibition, in the whole organism at one dose (the size of the read-out at that dose, not a potency): 69%
Beside the measured number, compound 4's estimate is 17 percentage points below it; the measured number lies above the stated range.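

In this assay, benzoyl on a saturated chain carbon bound to a sulfur gave a number 2 percentage points lower from compound 3 to compound 4 (within the scatter), so the change did not carry over from one core to the other at the same size: the same change on two cores in this assay, a number 19 percentage points lower (beyond the scatter) from compound 2 to compound 1 and a number 2 percentage points lower (within the scatter) from compound 3 to compound 4, 17 percentage points apart, beyond the scatter of two such steps Ethyl in place of phenyl on an aromatic nitrogen gave a number 10 percentage points higher from compound 1 to compound 4 (within the scatter), and this pair of steps also differs: the same change on two cores in this assay, a number 7 percentage points lower (within the scatter) from compound 2 to compound 3 and a number 10 percentage points higher (within the scatter) from compound 1 to compound 4, 17 percentage points apart, beyond the scatter of two such steps The size of the benzoyl step therefore depended on the core in these four compounds, but this does not show how the change would behave on any other core, or what underlies the difference.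

The compounds shown leave open how a methyl or a longer chain on the aromatic nitrogen would affect this step. They also leave open what an amine or a carboxylic acid in place of benzoyl would give.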